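The source may hold more compounds than are shown below. What is called first, only, known or untested is meant among the compounds shown, and "the series" means these compounds.

Working notes on the pyridine-carboxamide series.

Compound 1 `O=C(Nc1nn[nH]n1)c1cc(Cl)cc(-c2ccccc2)n1` is the parent of the pair measured so far. In a functional assay on the whole organism with Rattus norvegicus as the target, at a dose of 1 mg/kg by the oral route (a lower number here means a weaker effect, a higher number a stronger effect of the compound at the dose given), compound 1 gives 40%. Compound 2 `CCCCc1ccc(-c2cc(Cl)cc(C(=O)Nc3nn[nH]n3)n2)cc1` carries butyl in place of hydrogen on an aromatic carbon of the pendant ring. In this assay compound 2 gives 0%. Among the compounds with values here, the one step recorded, a number 40 percentage points lower from compound 1 to compound 2 (beyond the scatter), is large and lies beyond the scatter. Compound 2 therefore stands lowest of the two numbers, and its nearest neighbour is compound 1, higher by the same large step.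

The next compound, compound 3 `Nc1ccc(-c2cc(Cl)cc(C(=O)Nc3nn[nH]n3)n2)cc1`, differs from compound 2 in one place: amino in place of butyl on an aromatic carbon. Within the data shown here, the only measured step that bears on this change is a number 40 percentage points lower from compound 1 to compound 2 (beyond the scatter), which shows that putting butyl onto this aromatic carbon lowered the read-out by a large amount. Among the measured compounds shown here, removing butyl again may recover part of that loss, but the entering group is amino rather than hydrogen, and no measured compound shows what amino does here. The expected step is therefore an increase of moderate size, a number 25 percentage points higher from compound 2 to compound 3 (beyond the scatter), with wide uncertainty. Compound 3 is estimated at 25% in this assay, with a range from 0% to 50%.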

Compound 3, a percentage reported as inhibition, in the whole organism at one dose (the size of the read-out at that dose, not a potency): 100%
Beside the measured number, compound 3's estimate is 75 percentage points below it; the measured number lies above the stated range.
By their numbers in this assay, from the lowest: compound 2; then compound 1; then compound 3.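

At this aromatic carbon, para to a large group, substitution does not simply cost effect in this assay: amino in place of hydrogen gives a number 60 percentage points higher from compound 1 to compound 3 (beyond the scatter), the opposite direction to the loss seen with butyl. The exchange of butyl for amino gives a number 100 percentage points higher from compound 2 to compound 3 (beyond the scatter), which spans the full range of the three compounds and leaves compound 3 highest, with both of its steps beyond the scatter. The position is therefore sensitive to the identity of the group in both directions, but nothing measured here accounts for the difference between amino and butyl.

Butyl and amino differ at once in heavy atoms and in hydrogen-bond donors and acceptors, so the two compounds cannot show which difference tracks the read-out; a hydroxyl group, a methoxy group, a methylamino group or a short chain such as methyl at the same carbon would begin to separate these. Also open, going by these compounds, is how compound 3 behaves at doses other than the single oral dose given, since one dose gives the size of the read-out and not a potency.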